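Compound 3 in dog liver microsomes: estimating clearance

The source may hold more compounds than are shown below. What is called first, only, known or untested is meant among the compounds shown, and "the series" means these compounds.

Compound 1 `Cc1cccc(N2C(=O)CSC2c2cccc(C(=O)NCCCCc3ccccc3)c2)c1`: 749 mL.min-1.g-1
Compound 2 `O=C(NCCCCc1ccccc1)c1cccc(C2SCC(=O)N2c2ccccn2)c1`: 492 mL.min-1.g-1

Both numbers come from an ADME assay on microsomes from liver (Canis lupus familiaris) for metabolic stability, read by LC-MS, using NADPH, with a stated time of 10 min, tested at 0.1 uM; a higher number here means faster removal of the compound, a lower number slower removal. Among the measured compounds shown here, compound 2 cannot be told apart from compound 1, the only other compound measured so far. For the measured compounds named here, the one measured step between them, a 1.5-fold lower number from compound 1 to compound 2 (0.18 log units; within the scatter), puts pyridin-2-yl in place of 3-methylphenyl on an amide-type nitrogen in a ring.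

The next structure is compound 3 `C#Cc1cccc(N2C(=O)CSC2c2cccc(C(=O)NCCCCc3ccccc3)c2)c1`, which changes the group at that same nitrogen: 3-ethynylphenyl in place of pyridin-2-yl on an amide-type nitrogen in a ring. In words, 3-ethynylphenyl replaces pyridin-2-yl. Like compound 1, compound 3 carries there an aromatic ring of carbon only, so the measured step is the closest guide, read in reverse. Going by the values given here, the ethynyl group itself has no measured precedent here, and one small step is thin evidence. A modest rise in this assay is therefore expected, with nothing clearly beyond the scatter. The expected change is a 1.4-fold higher number from compound 2 to compound 3 (0.15 log units; within the scatter). Compound 3 is estimated at 700 mL.min-1.g-1, with an expected range from 320 mL.min-1.g-1 to 1500 mL.min-1.g-1.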

Compound 3, intrinsic clearance in microsomes: 973 mL.min-1.g-1
The estimate for compound 3 lay 1.4-fold (0.14 log units) below the measured number; measured number inside the range.
By their numbers in this assay, from the lowest: compounds 2, 1 and 3 (each within the scatter of the next).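

In this assay, the step of a 2.0-fold higher number from compound 2 to compound 3 (0.30 log units; within the scatter) lies within the scatter, so at this amide-type nitrogen 3-ethynylphenyl cannot be told apart from pyridin-2-yl, even though it brings a triple bond and no ring nitrogen. Among the compounds shown here, the step of a 1.3-fold higher number from compound 1 to compound 3 (0.11 log units; within the scatter) is the first comparison here of a change on the aromatic ring itself, ethynyl in place of methyl on an aromatic carbon, and it also lies within the scatter. No measurement at hand bears on why these three compounds sit so close together.

From the compounds shown here alone, all three groups on this nitrogen are six-membered aromatic rings, so it remains open whether a cyclohexyl ring or a short chain such as ethyl in their place would move the number beyond the scatter. Going by these compounds, it also remains open whether a carboxylic acid or an amine in place of the ethynyl would do so, as only methyl and ethynyl have been compared on that carbon.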